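A few compounds are considered here, and "the series" means these few. Any claim that something is new, unique, unknown or untested is made for them only; others in the source may bear on it.

Compound 3 `Cc1c(C(=O)Nc2c(F)cc(-c3cccc(F)c3)cc2F)nc2ccc(F)cc2c1C(=O)O` gives the highest of the three numbers in a functional assay on A-375 cells (Homo sapiens) for antiproliferative activity, read by MTT assay, with a stated time of 24 h, tested at 33.33 ug/mL; a higher number here means a stronger effect of the compound at the concentration tested, a lower number a weaker effect. Compound 2 `Cc1c(C(=O)Nc2c(F)cc(-c3cccc(F)c3)cc2F)nc2ccc(F)cc2c1O` gives 28.8% in this assay, and the step of a number 12.5 percentage points higher from compound 2 to compound 3 (beyond the scatter) in this assay separates it from compound 3, which gives 41.3%. Compound 1 `CCc1ccc2nc(C(=O)Nc3c(F)cc(-c4cccc(F)c4)cc3F)c(C)c(O)c2c1` gives 28.4% in this assay, and the step of a number 0.4 percentage points higher from compound 1 to compound 2 (within the scatter) in this assay shows that this exchange on an aromatic carbon left the read-out essentially unchanged.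

Compound 4 `COc1ccc2nc(C(=O)Nc3c(F)cc(-c4cccc(F)c4)cc3F)c(C)c(C(=O)O)c2c1` differs from compound 3 in one place: methoxy in place of fluoro on an aromatic carbon. The step that bears on this exchange is a number 0.4 percentage points higher from compound 1 to compound 2 (within the scatter), since it also replaced a group on an aromatic carbon of the shared core while the rest stayed fixed, and it stayed within the scatter. Among the compounds with values here, no measured step tests methoxy itself. The step of a number 1.3 percentage points lower from compound 3 to compound 4 (within the scatter) is therefore expected to stay small in either direction. Compound 4 is accordingly estimated to give 40% in this assay, with a range from 28% to 52%.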

Compound 4, a percentage reported as inhibition, at one concentration (the size of the read-out at that concentration, not a potency): 44.5%
Estimate against measurement, compound 4: 4.5 percentage points below, within the range that was stated.
By their numbers in this assay, from the lowest: compounds 1 and 2 (each within the scatter of the next); then compounds 3 and 4 (each within the scatter of the next).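

Methoxy in place of fluoro on this aromatic carbon, meta to a fused ring and para to a fused ring, gives a number 3.2 percentage points higher from compound 3 to compound 4 (within the scatter) in this assay, so a group with an oxygen acceptor enters here without moving the read-out beyond the scatter. Alongside a number 0.4 percentage points higher from compound 1 to compound 2 (within the scatter), this is a second exchange at this carbon that stays within the scatter, now with carboxy rather than hydroxy on the shared core, whereas the exchange at the other place gives a number 12.5 percentage points higher from compound 2 to compound 3 (beyond the scatter). Nothing given here accounts for this outcome.

As far as these compounds go, whether an amine or a carboxylic acid on this aromatic carbon would also leave the read-out in place remains open. From the compounds shown here alone, all four numbers are read-outs at a single concentration, so how the compounds compare in potency is also open.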